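From carbamoyl to 3-aminopropyl: will buffer stability hold?

The compounds below may be only part of what the source reports. "The series", "measured", "known", "first", "only" and "open" are said of these compounds alone.

Results in a physicochemical assay, read by HPLC, in phosphate buffer, with a stated time of 24 h, at pH 7.4 (on this read-out higher numbers stand for a more stable compound and lower numbers for a less stable compound), are these:

- Compound 1 `CCCCCc1ccc(-c2cc3cn([C@H]4C[C@H](OC(=O)[C@@H](NC(=O)[C@@H]5CCCN5C(=O)[C@@H](N)C(C)C)C(C)C)[C@@H](CO)O4)c(=O)nc3o2)cc1` gives > 95% as a limit, not a number
- Compound 2 `CCCCCc1ccc(-c2cc3cn([C@H]4C[C@H](O)[C@@H](COC(=O)[C@H](C)NC(=O)[C@@H]5CCCN5C(=O)[C@@H](N)C(C)C)O4)c(=O)nc3o2)cc1` gives 74% as a number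
- Compound 3 `CCCCCc1ccc(-c2cc3cn([C@H]4C[C@H](O)[C@@H](COC(=O)[C@@H](NC(=O)[C@@H]5CCCN5C(=O)[C@@H](N)CC(N)=O)C(C)C)O4)c(=O)nc3o2)cc1` gives > 95% as a limit, not a number

Compound 3 stands at > 95% as a limit, not a number (the limit of > 95% in this assay, at which 2 of the 3 values shown sit). Compound 4 `CCCCCc1ccc(-c2cc3cn([C@H]4C[C@H](O)[C@@H](COC(=O)[C@@H](NC(=O)[C@@H]5CCCN5C(=O)[C@@H](N)CCCCN)C(C)C)O4)c(=O)nc3o2)cc1` carries one change (3-aminopropyl in place of carbamoyl on a saturated chain carbon, two bonds along the chain from an amine nitrogen and a carbonyl carbon): 3-aminopropyl in place of carbamoyl on a saturated chain carbon, two bonds along the chain from an amine nitrogen and a carbonyl carbon. Among the measured compounds shown here, no measured pair shows what this swap does, so the expectation starts from compound 3 alone, with its limit of > 95% as the reference. The expected change in this assay is small (a number at least 1 percentage points lower from compound 3 to compound 4 (that floor lies within the scatter)), with no shift beyond the usual scatter. Compound 4 is estimated at 94% with a range from 84% to 100% in this measurement.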

Compound 4, percent of the compound remaining: > 95%
Compound 4: only a limit was reported; the forecaster's own chance of this, stated with the estimate: 60%; at least 1 percentage points between middle value and limit.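

No step from compound 3 to compound 4 can be read, since both results are limits rather than numbers: the limit of > 95% in this assay, at which 3 of the 4 values shown sit.

The compounds shown leave open whether 3-aminopropyl in place of carbamoyl changes stability in buffer at all.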